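Removing the methoxy group: transfer across two cores

A few compounds are considered here, and "the series" means these few. Any claim that something is new, unique, unknown or untested is made for them only; others in the source may bear on it.

Compound 1 `COc1ccc(-c2nc(C)c(C(=O)CSc3nc(N)c(C#N)c(-c4ccccc4)n3)s2)cc1` and compound 2 `Cc1nc(-c2ccccc2)sc1C(=O)CSc1nc(N)c(C#N)c(-c2ccccc2)n1` share one core; compound 3 `COc1ccc(-c2nc(SCC(=O)c3sc(-c4ccc(Cl)cc4)nc3C)nc(N)c2C#N)cc1` and compound 4 `Cc1nc(-c2ccc(Cl)cc2)sc1C(=O)CSc1nc(N)c(C#N)c(-c2ccccc2)n1` share another, and the difference between the two cores is not broken down here. In a functional assay on U-87MG ATCC cells for antiproliferative activity against U-87 MG (Homo sapiens), read by MTT assay, with a stated time of 48 h, tested at 5 uM (on this read-out higher numbers stand for a weaker effect at the one concentration tested and lower numbers for a stronger effect), compound 1 gives 61.8%, compound 2 gives 103%, and compound 3 gives 69.7%. The change from compound 1 to compound 2 is hydrogen in place of methoxy on an aromatic carbon and it made the step of a number 41.2 percentage points higher from compound 1 to compound 2 (beyond the scatter). Among the compounds with values here, the change from compound 3 to compound 4 is hydrogen in place of methoxy on an aromatic carbon; the place is the same in both pairs, so this is the same change carried onto a second core, with only one earlier instance to rest on. Compound 4 is expected to shift by a number 28.3 percentage points higher from compound 3 to compound 4 (beyond the scatter) beside the earlier step because the step of a number 41.2 percentage points higher from compound 1 to compound 2 (beyond the scatter) was large. The estimate for compound 4 is 98%, expected between 80% and 112%.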

Compound 4, a percentage reported as activity, at one concentration (the size of the read-out at that concentration, not a potency): 71.1%
The estimate for compound 4 lay 26.9 percentage points above the measured number; measured number below the stated range.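

Hydrogen in place of methoxy does not carry over in size between these two cores in this assay: the same change on two cores in this assay, a number 41.2 percentage points higher (beyond the scatter) from compound 1 to compound 2 and a number 1.4 percentage points higher (within the scatter) from compound 3 to compound 4, 39.8 percentage points apart, beyond the scatter of two such steps. On the second core the change gives a number 1.4 percentage points higher from compound 3 to compound 4 (within the scatter), whereas chloro in place of hydrogen gives a number 31.9 percentage points lower from compound 2 to compound 4 (beyond the scatter) and chloro in place of methoxy gives a number 9.3 percentage points higher from compound 1 to compound 4 (within the scatter). Only compound 2 stands apart from the other three, and two pairs neither set a rule for further cores nor explain the gap.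

Still open, on these data alone, is how an amine, a hydroxyl or a fluoro group in that place would read on either core. A read-out at one concentration also tells only of a stronger or weaker effect at that concentration.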